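The compounds below may be only part of what the source reports. "The series", "measured", "known", "first", "only" and "open" are said of these compounds alone.

Measured so far in a functional assay on NCI-H460 cells (Homo sapiens) for antiproliferative activity, read by XTT assay, with a stated time of 72 h; on this read-out lower numbers stand for stronger inhibition and higher numbers for weaker inhibition:
compound 1, `COc1ccc(-c2cc3ccccc3nc2/C=C/C(=O)c2ccccc2)cc1` — 6670 nM
compound 2, `COc1ccc(-c2cc3ccccc3nc2/C=C/C(=O)c2ccc(OC)cc2OC)cc1` — 7040 nM

Compound 2 has a single neighbour among the measured compounds, compound 1, and the two values lie within the scatter of each other; no separation between them can be claimed from these numbers. Within the data shown here, the one step available, a 1.1-fold higher number from compound 1 to compound 2 (0.02 log units; within the scatter), swaps the aryl group on the carbonyl carbon and leaves the read-out essentially unchanged.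

Compound 3, `COc1ccc(-c2cc3ccccc3nc2/C=C/C(=O)c2ccc([N+](=O)[O-])cc2)cc1`, is not yet measured. Its difference from compound 2 is 4-nitrophenyl in place of 2,4-dimethoxyphenyl on a carbonyl carbon. This is again a change of the aryl group on the carbonyl carbon, the same position that was varied in the step from compound 1 to compound 2, which bears directly on it. Since that step stayed within the scatter, no step beyond the scatter is expected here either; the direction is left open. The estimate for compound 3 in this assay is therefore 6500 nM, with a range from 2500 nM to 16000 nM, which corresponds to an expected step of a 1.1-fold lower number from compound 2 to compound 3 (0.03 log units; within the scatter).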

Compound 3, half-maximal inhibitory concentration: 6470 nM
Compound 3: middle estimate off by 1.0-fold (0.00 log units), on the high side; the measured number falls inside the stated range.
By their numbers in this assay, from the lowest: compounds 3, 1 and 2 (each within the scatter of the next).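

In this assay the aryl group on the carbonyl carbon now spans phenyl, 2,4-dimethoxyphenyl and 4-nitrophenyl, and the swap of the dimethoxy ring for the nitro ring gives a 1.1-fold lower number from compound 2 to compound 3 (0.04 log units; within the scatter) while nitro in place of hydrogen on an aromatic carbon gives a 1.0-fold lower number from compound 1 to compound 3 (0.01 log units; within the scatter) so none of the three can be separated from another. Until now the lack of separation rested on one pair and on methoxy groups alone; it now also covers a group with nitrogen and a double bond outside aromatic rings, and none of the three compounds goes against it, though the observation extends no further than these three. No supporting data on hand bear on why this position shows no separation in this series.

Still open, on these data alone, is whether the same holds once the aryl group on the carbonyl carbon gives way to something other than a substituted phenyl, such as a saturated alkyl chain, or once that phenyl carries an amine or a carboxylic acid. As far as these compounds go, the shared core and the double-bonded chain also remain untested as places of change, so what, if anything, moves the read-out cannot yet be said.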